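Cytotoxicity notes: hydrazone aryl swap on the shared core

This account rests on a few compounds, and the source may have more. Where it says the series, first, only, none or still open, it means among the compounds named here.

Measured so far:
compound 1 `COc1ccccc1-c1nnc(-c2ccc(C(=O)N/N=C/c3cccc(O)c3)cc2)o1` — 398000 nM
compound 2 `COc1ccccc1-c1nnc(-c2ccc(C(=O)N/N=C/c3c(O)cc(O)cc3O)cc2)o1` — 12400 nM

Going by the values given here, compound 2 holds the lowest number of the two in an ADME assay on THP-1 cells (Homo sapiens) for cytotoxicity; on this read-out lower numbers stand for stronger inhibition and higher numbers for weaker inhibition; its nearest neighbour is compound 1, and the only measured step, a 32-fold lower number from compound 1 to compound 2 (1.51 log units; beyond the scatter), ties the 2,4,6-trihydroxyphenyl group to that drop. Among the compounds with values here, no other pair has been run.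

Compound 3 `COc1ccccc1-c1nnc(-c2ccc(C(=O)N/N=C/c3ccccn3)cc2)o1` has not been tested. The change from compound 2 is pyridin-2-yl in place of 2,4,6-trihydroxyphenyl on a carbon with a double bond to nitrogen. This step is not a reversal of the measured one, but it bears on the same position and strips the three hydroxyls that distinguished compound 2 from compound 1. Within the data shown here, the one relevant step, a 32-fold lower number from compound 1 to compound 2 (1.51 log units; beyond the scatter), was large, so a large move back toward higher numbers in this assay is expected when the hydroxyl-bearing ring is replaced. Compound 3 is therefore estimated at 200000 nM, with a range of 40000 nM to 1000000 nM, which means an expected step of a 16-fold higher number from compound 2 to compound 3 (1.21 log units; beyond the scatter). A readout that is only a limit is plausible for compound 3.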

Compound 3, half-maximal inhibitory concentration: 67000 nM
Compound 3: the middle estimate sits 3.0-fold (0.47 log units) above what was measured; low and high end bracket the measured number.
By their numbers in this assay, from the lowest: compound 2; then compound 3; then compound 1.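

On a carbon with a double bond to nitrogen, the numbers in this assay do not simply follow the hydroxyl groups on the ring: pyridin-2-yl has no hydrogen-bond donor, yet replacing 3-hydroxyphenyl with it gives a 5.9-fold lower number from compound 1 to compound 3 (0.77 log units; beyond the scatter). Replacing 2,4,6-trihydroxyphenyl with pyridin-2-yl gives a 5.4-fold higher number from compound 2 to compound 3 (0.73 log units; beyond the scatter), so this change moves the number back up but does not return it to the level of compound 1, and the aryl group at this place can shift the read-out in more than one way. No measurement available here explains either step.

The compounds shown leave open whether the ring nitrogen of pyridin-2-yl contributes to the lower number relative to compound 1, or whether removing the hydroxyl alone would do the same; an unsubstituted phenyl group on the same carbon would separate these two readings. A pyridin-4-yl group or an aminophenyl group in that place would further test whether the effect belongs specifically to pyridin-2-yl.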